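Adding a Methyl to the Ring Amine of Compound 2

The source may report more compounds than this note shows. Statements on the series, on what has been measured and on what is new or still open speak of the compounds shown alone.

Compound 2 `CC(C)Oc1cncc(C2=CC3CNCC(C2)C3)c1` stands at the higher end of the two numbers seen so far: in an in vitro functional assay on SH-EP1 cells for agonist activity at Neuronal acetylcholine receptor; alpha4/beta2 (Homo sapiens), read by FLIPR and calcium flux (on this read-out higher numbers stand for an effect only at larger amounts of compound and lower numbers for an effect already at smaller amounts), compound 2 gives 562 nM, while compound 1 `C1=C(c2cncnc2)CC2CNCC1C2` gives 162 nM, a gap beyond the usual scatter. Compound 3 `CC(C)Oc1cncc(C2=CC3CC(C2)CN(C)C3)c1` differs from compound 2 by a single change: methyl in place of hydrogen on an amine nitrogen in a ring. Within the data shown here, no measured pair shows this change, so its size is not known from the data. The expected step of a 2.7-fold higher number from compound 2 to compound 3 (0.43 log units; beyond the scatter) points toward an effect only at larger amounts of compound. For compound 3 the estimate in this assay is 1500 nM, with a range from 400 nM to 6000 nM.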

Compound 3, half-maximal effective concentration: > 10000 nM
Compound 3 ended at the assay's limit; the forecaster's own chance of this, stated with the estimate: 15%; middle value at least 6.6-fold (0.82 log units) from the limit.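

Even a single added carbon matters at this position: methyl in place of hydrogen on the ring amine nitrogen brings an at least 17-fold higher number from compound 2 to compound 3 (1.25 log units; beyond the scatter), the first measured sign that this nitrogen tolerates little change. In this assay compound 3 gives > 10000 nM, which is a limit of the assay and not a number, so the step shows only a minimum size.

As far as these compounds go, whether an ethyl or a benzyl group on this nitrogen would behave like methyl stays open. So does whether methyl would have a similar effect on compound 1.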